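The source may hold more compounds than are shown below. What is called first, only, known or untested is meant among the compounds shown, and "the series" means these compounds.

Working notes on the series. Compound 1 `CC(=O)c1ccc(OCc2cccc([N+](=O)[O-])c2)cc1` and compound 2 `CC(=O)c1ccc(OCc2cccc(C(F)(F)F)c2)cc1` share a core; in an assay on isolated protein for inhibition of Amine oxidase [flavin-containing] B (Homo sapiens), read by Amplex Red, with a stated time of 15 min (on this read-out higher numbers stand for weaker inhibition and lower numbers for stronger inhibition), compound 1 gives 104 nM and compound 2 gives 58.2 nM. The difference between them is nitro in place of trifluoromethyl on an aromatic carbon, and the step was a 1.8-fold higher number from compound 2 to compound 1 (0.25 log units; within the scatter). Compound 3 `CC(=O)c1cccc(OCc2ccc(C(F)(F)F)cc2)c1` carries a different core; how its core differs from that of compound 2 is not broken down here. In this assay compound 3 gives 43.2 nM.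

Compound 4 `CC(=O)c1cccc(OCc2ccc([N+](=O)[O-])cc2)c1` is not yet measured. Relative to compound 3 it shows (nitro in place of trifluoromethyl on an aromatic carbon), the same kind of change as that from compound 2 to compound 1, though the place differs: there the nitro sat meta to a large group, here it sits para to a large group. Given the step of a 1.8-fold higher number from compound 2 to compound 1 (0.25 log units; within the scatter), the expected step from compound 3 to compound 4 in this assay is a 1.8-fold higher number from compound 3 to compound 4 (0.26 log units; within the scatter). Compound 4 is therefore estimated at 78 nM, between 35 nM and 175 nM.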

Compound 4, half-maximal inhibitory concentration: 75.4 nM
Compound 4: middle estimate off by 1.0-fold (0.01 log units), on the high side; the range from low to high includes it.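

In this assay, nitro in place of trifluoromethyl gives a 1.7-fold higher number from compound 3 to compound 4 (0.24 log units; within the scatter), and this step sits close to the earlier one on the other core: the same change on two cores in this assay, a 1.8-fold higher number (0.25 log units; within the scatter) from compound 2 to compound 1 and a 1.7-fold higher number (0.24 log units; within the scatter) from compound 3 to compound 4, 1.0-fold (0.01 log units) apart, within the scatter of two such steps. Across these two pairs, the change carries from the core of compound 2 to the core of compound 3 with no visible difference in the size of the step. Both steps lie within the scatter, however, so neither pair shows that nitro and trifluoromethyl truly differ in this assay, and two cores cannot speak for the rest of the series.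

As far as these compounds go, it remains open how an amine or a carboxylic acid on the same aromatic carbon would compare with nitro and trifluoromethyl on these cores.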